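The source may report more compounds than this note shows. Statements on the series, on what has been measured and on what is new or still open speak of the compounds shown alone.

Of the compounds shown here, three have so far been measured in a functional assay on PC-3 cells (Homo sapiens) for antiproliferative activity, read by MTT assay, tested at 1 uM; on this read-out higher numbers stand for a stronger effect at the one concentration tested and lower numbers for a weaker effect. Compound 1, `COc1ccc(/C=N/NC(=O)c2cc(OC)c(OC)c(OC)c2)c(OC)c1`, gives 10% in this assay. Compound 2, `COc1cc(C2=NN(C(C)=O)C(c3ccc(F)c(F)c3)O2)cc(OC)c1OC`, gives 35.5% in this assay. Compound 3, `COc1cc(C(=O)N/N=C/c2cccc(C(F)(F)F)c2)cc(OC)c1OC`, gives 51% in this assay. Compound 2 thus stands second highest of the three numbers; compound 3 lies above it by a margin beyond the usual scatter, and compound 1 lies below it by a margin that is also beyond the scatter.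

Compound 4, `COc1ccc(OC)c(C2OC(c3cc(OC)c(OC)c(OC)c3)=NN2C(C)=O)c1`, has not yet been measured in this assay. It differs from compound 2 in one place: 2,5-dimethoxyphenyl in place of 3,4-difluorophenyl on a saturated ring carbon. Going by the values given here, no measured pair of compounds shows this change, so the size of the step can only be guessed from the spread of the three numbers already in hand. Compound 1, the one that carries a methoxy-bearing aryl group on its hydrazone, gives 10%, the lowest of the set, and on that slender basis a small fall, or no change beyond the scatter, is expected. The step from compound 2 to compound 4 is accordingly estimated at a number 8.5 percentage points lower from compound 2 to compound 4 (within the scatter). Compound 4 is expected to give about 27% in this assay, within a range from 12% to 44%.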

Compound 4, a percentage reported as inhibition, at one concentration (the size of the read-out at that concentration, not a potency): 37.2%
The estimate for compound 4 lay 10.2 percentage points below the measured number; the measured number falls inside the stated range.
By their numbers in this assay, from the lowest: compound 1; then compounds 2 and 4 (each within the scatter of the next); then compound 3.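

In this assay, going by these compounds alone, the exchange of 3,4-difluorophenyl for 2,5-dimethoxyphenyl on the saturated ring carbon amounts to a number 1.7 percentage points higher from compound 2 to compound 4 (within the scatter) and gives the first direct reading of a change at this position. Within this one pair, the read-out does not separate the two aryl groups: the six-membered aromatic carbon ring stays, the two fluorine atoms give way to two methoxy groups with their hydrogen-bond acceptors, and the number stays within the scatter at the single concentration tested. No measurement of any property of either group is at hand to account for this result.

The compounds shown leave open whether this position would respond the same way to a group of another kind, such as an amine, a carboxylic acid or a longer alkyl chain in place of the aryl ring. They also leave open what part the acetyl group on the ring nitrogen plays, since compound 2 and compound 4 both carry it and neither has, for instance, a propionyl group there.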